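A few compounds are considered here, and "the series" means these few. Any claim that something is new, unique, unknown or untested is made for them only; others in the source may bear on it.

Compound 1 `CC(C)(Oc1ccccc1)C1OCC(C/C=C\CCC(=O)O)C(c2cccnc2)O1`: 75.9 nM
Compound 2 `CC(C)(C)c1ccc(OC(C)(C)C2OCC(C/C=C\CCC(=O)O)C(c3cccnc3)O2)cc1`: 1910 nM
Compound 3 `Cc1ccc(OC(C)(C)C2OCC(C/C=C\CCC(=O)O)C(c3cccnc3)O2)cc1`: 631 nM

In a functional assay for inhibition, with Homo sapiens as the target (a higher number here means weaker binding, a lower number tighter binding), compound 3 holds the middle of the three numbers, lower than compound 2 and higher than compound 1. Compound 4 `CC(C)(Oc1ccccc1F)C1OCC(C/C=C\CCC(=O)O)C(c2cccnc2)O1` differs from it by one change: 2-fluorophenyl in place of 4-methylphenyl on an oxygen on a saturated carbon, with 2-fluorophenyl in place of 4-methylphenyl on an oxygen on a saturated carbon. Among the measured compounds shown here, two measured steps bear on this. Methyl in place of hydrogen on an aromatic carbon gave an 8.3-fold higher number from compound 1 to compound 3 (0.92 log units; beyond the scatter), and tert-butyl gave a 25-fold higher number from compound 1 to compound 2 (1.40 log units; beyond the scatter). Losing the 4-methylphenyl should therefore undo much of the first step, although no fluorine-bearing compound has been measured. The expected change is modest and downward, a 4.9-fold lower number from compound 3 to compound 4 (0.69 log units; beyond the scatter). For compound 4 the estimated value is 130 nM, with an expected range of 45 nM to 380 nM.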

Compound 4, dissociation constant: 166 nM
The estimate for compound 4 lay 1.3-fold (0.11 log units) below the measured number; measured number inside the range.
By their numbers in this assay, from the lowest: compound 1; then compound 4; then compound 3; then compound 2.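

In this assay, fluoro in place of hydrogen also costs binding, with a 2.2-fold higher number from compound 1 to compound 4 (0.34 log units; beyond the scatter), so no substituent shown on this aromatic ring improves on the plain phenyl of compound 1. The 2-fluorophenyl group is nevertheless far better tolerated than the larger groups, with a 3.8-fold lower number from compound 3 to compound 4 (0.58 log units; beyond the scatter) and a 12-fold lower number from compound 2 to compound 4 (1.06 log units; beyond the scatter). Nothing measured here explains these differences. The steps from compound 2 and compound 3 change both the group and its ring position, so those two effects remain unseparated. Pairing 4-fluorophenyl with 2-methylphenyl would separate them.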